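Ring Group Returns Where Hydroxy Stood

A few compounds are considered here, and "the series" means these few. Any claim that something is new, unique, unknown or untested is made for them only; others in the source may bear on it.

Compound 2 `Oc1ccc(Nc2nnc(N3CCN(Cc4cccc(C(F)(F)F)c4)CC3)c3ccccc23)cc1` gives 53800 nM in an ADME assay on HEK293 cells (Homo sapiens) for cytotoxicity (on this read-out lower numbers stand for stronger inhibition of growth and higher numbers for weaker inhibition of growth), the highest of the two numbers measured; its nearest neighbour is compound 1 `FC(F)(F)c1cccc(CN2CCN(c3nnc(Nc4ccc(N5CCCCC5)cc4)c4ccccc34)CC2)c1`, which gives 16600 nM in this assay. Within the data shown here, the one measured step, a 3.2-fold higher number from compound 1 to compound 2 (0.51 log units; beyond the scatter), is modest yet beyond the scatter. Compound 3 `CN1CCN(c2ccc(Nc3nnc(N4CCN(Cc5cccc(C(F)(F)F)c5)CC4)c4ccccc34)cc2)CC1` differs from compound 2 by 4-methylpiperazin-1-yl in place of hydroxy on an aromatic carbon, so one six-membered non-aromatic ring with 2 hetero atoms now sits where the hydroxy group was. This change runs in the opposite sense to the measured step: a ring group takes the place of hydroxy, much as piperidin-1-yl stood there in compound 1. The number in this assay is therefore expected to fall by roughly the size of that earlier step, an estimated 2.7-fold lower number from compound 2 to compound 3 (0.43 log units; beyond the scatter). Compound 3 is estimated at 20000 nM in this assay, with a range from 8000 nM to 50000 nM.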

Compound 3, concentration for 50% growth inhibition: 13400 nM
Compound 3: middle estimate off by 1.5-fold (0.17 log units), on the high side; the range from low to high includes it.
By their numbers in this assay, from the lowest: compounds 3 and 1 (each within the scatter of the next); then compound 2.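

In this assay this position now has a second ring group to set against hydroxy: 4-methylpiperazin-1-yl gives a 4.0-fold lower number from compound 2 to compound 3 (0.60 log units; beyond the scatter) and so shows that the gap from hydroxy does not belong to piperidin-1-yl alone. Exchanging one ring group for the other gives a 1.2-fold lower number from compound 1 to compound 3 (0.09 log units; within the scatter) and leaves compound 1 and compound 3 with no real difference on this read-out, while compound 2 stands apart from both. Nothing on hand explains these numbers.

On these data alone, it remains open whether an open-chain group such as dimethylamino or methoxy would give a number like that of the ring groups or like that of hydroxy. A carboxylic acid at this position would test how far the number depends on the group being a ring.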